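Aryl sulfonamide series: methoxy for ethyl at the aniline

This account rests on a few compounds, and the source may have more. Where it says the series, first, only, none or still open, it means among the compounds named here.

Measured so far in a functional assay on HT-29 cells (Homo sapiens) for antiproliferative activity, read by sulforhodamine B assay, with a stated time of 48 h; a higher number here means a weaker inhibitor, a lower number a stronger inhibitor:
Compound 1 `CCc1ccccc1NS(=O)(=O)c1ccc(N2CCNC2=O)cc1` gives 240 nM.
Compound 2 `O=C1NCCN1c1ccc(S(=O)(=O)Nc2ccc(Cl)cc2)cc1` gives 220 nM.
Compound 3 `COc1ccc(NS(=O)(=O)c2ccc(N3CCNC3=O)cc2)cc1OC` gives 520 nM.

Compound 1 stands second highest of the three numbers. Its nearest neighbour is compound 2, with a 1.1-fold lower number from compound 1 to compound 2 (0.04 log units; within the scatter), a step within the scatter that swaps one aryl substituent pattern for another on the sulfonamide nitrogen without a change in this assay. The furthest is compound 3, whose number is beyond the scatter from that of compound 1; the two differ in more than one place, so only the two values themselves can be compared.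

Compound 4 `COc1ccccc1NS(=O)(=O)c1ccc(N2CCNC2=O)cc1` is not yet measured. It differs from compound 1 as follows: methoxy in place of ethyl on an aromatic carbon.

Among the compounds with values here, only the step from compound 1 to compound 2 bears on this change, and it showed no movement. The values of compound 3, which carries two methoxy groups, lean slightly toward a higher number. For compound 4 the expected step is a 1.3-fold higher number from compound 1 to compound 4 (0.10 log units; within the scatter), that is, no change beyond the scatter, with a slight lean to a higher number. Compound 4 is therefore estimated at 300 nM, with a range from 150 nM to 650 nM.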

Compound 4, half-maximal inhibitory concentration: 550 nM
The estimate for compound 4 lay 1.8-fold (0.26 log units) below the measured number; the range from low to high includes it.
By their numbers in this assay, from the lowest: compounds 2 and 1 (each within the scatter of the next); then compounds 3 and 4 (each within the scatter of the next).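

In this assay the change from ethyl to methoxy on this aromatic carbon, ortho to a large group, is not neutral: it gives a 2.3-fold higher number from compound 1 to compound 4 (0.36 log units; beyond the scatter) and so a modest step beyond the scatter, unlike the aryl exchange that gave a 1.1-fold lower number from compound 1 to compound 2 (0.04 log units; within the scatter) and stayed within it. The 2-methoxyphenyl group also stands apart from the 4-chlorophenyl group, with a 2.5-fold higher number from compound 2 to compound 4 (0.40 log units; beyond the scatter) in the same direction. Both groups count 2 heavy atoms, and the counted difference is one oxygen for one carbon and one added hydrogen-bond acceptor, but no measurement at hand explains the step.

An amine, a hydroxyl or a propyl chain on the same aromatic carbon lies outside the compounds shown. On these data alone, how far the number moves with such groups, and whether the oxygen itself matters, remains open.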